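Dropping the ring hydroxy from compound 2

This account rests on a few compounds, and the source may have more. Where it says the series, first, only, none or still open, it means among the compounds named here.

In a functional assay on PC-3 cells (Homo sapiens) for inhibition, read by MTT assay, with a stated time of 48 h, tested at 10 uM (a lower number here means less inhibition of growth, a higher number more inhibition of growth at the concentration tested), compound 2 (`Cc1cc(=O)c2c(O)c(CN3CC(O)CC3C(=O)O)c(O)c([C@H]3CCN(C)C[C@H]3O)c2o1`) gives 0% and compound 1 (`Cc1cc(=O)c2c(O)c(CN3CCCC3)c(O)c([C@H]3CCN(C)C[C@H]3O)c2o1`) gives 10%, so the two lie within the scatter of each other. Compound 3 (`Cc1cc(=O)c2c(O)c(CN3CCCC3C(=O)O)c(O)c([C@H]3CCN(C)C[C@H]3O)c2o1`) has hydrogen in place of hydroxy on a saturated ring carbon. Going by the values given here, the only measured step, a number 10 percentage points lower from compound 1 to compound 2 (within the scatter), bears on this indirectly, since it brings in carboxy and hydroxy together. Among the compounds with values here, no measured step isolates the hydroxy. The estimated step, a number 4 percentage points higher from compound 2 to compound 3 (within the scatter), is therefore expected to stay within the scatter. In this assay compound 3 is expected at 4%, with an estimated range of 0% to 15%.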

Compound 3, percent growth inhibition at one concentration: 0%
Beside the measured number, compound 3's estimate is 4 percentage points above it; measured number inside the range.
By their numbers in this assay, from the lowest: compounds 2, 3 and 1 (each within the scatter of the next).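

In this assay, hydrogen in place of hydroxy on the saturated ring carbon, read alone, gives no change at the digits printed from compound 2 to compound 3 (within the scatter), and carboxy in place of hydrogen, also read alone, gives a number 10 percentage points lower from compound 1 to compound 3 (within the scatter). The earlier step carried both groups together, and these two steps now separate them. Taken singly, neither group shifts the number beyond the scatter at this ring.

Still open, from the compounds shown here alone, is whether an amine or a methyl ester in place of the carboxy would give a number beyond the scatter. Nothing at hand gives a reason for either step.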